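From compound 2 to compound 4: a ring exchange

The source may report more compounds than this note shows. Statements on the series, on what has been measured and on what is new or still open speak of the compounds shown alone.

Measured in an ADME assay on Vero cells (Chlorocebus sabaeus) for cytotoxicity, read by MTT assay, with a stated time of 72 h; a higher number here means a weaker inhibitor, a lower number a stronger inhibitor:
- compound 1 `O=C(O)c1cn(C2CC2)c2nc(N3CCN(C(c4ccccc4)c4ccc(Cl)cc4)CC3)c([N+](=O)[O-])cc2c1=O`: 112000 nM
- compound 2 `CC1CN(c2nc3c(cc2[N+](=O)[O-])c(=O)c(C(=O)O)cn3C2CC2)CC(C)O1`: > 160000 nM (a limit)
- compound 3 `CCN(CC)C(=O)C1CCCN(c2nc3c(cc2[N+](=O)[O-])c(=O)c(C(=O)O)cn3C2CC2)C1`: > 136000 nM (a limit)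

Only compound 1 has a numerical reading. Compound 2 stands at the limit of > 160000 nM in this assay, at which 1 of the 3 values shown sits, so it has a limit and no number. Compound 3 likewise stands at the limit of > 136000 nM in this assay, at which 1 of the 3 values shown sits.

The next compound to be read is compound 4 `CC1(C)COCN1c1nc2c(cc1[N+](=O)[O-])c(=O)c(C(=O)O)cn2C1CC1`. It carries 4,4-dimethyl-1,3-oxazolidin-3-yl in place of 2,6-dimethylmorpholin-4-yl on an aromatic carbon, next to the ring nitrogen and ortho to a nitro group: 4,4-dimethyl-1,3-oxazolidin-3-yl in place of 2,6-dimethylmorpholin-4-yl on an aromatic carbon. The rest of the molecule is unchanged.

For the measured compounds named here, no pair of measured compounds differs in one place, so the size of this change has no direct precedent. In this assay, the estimated step of an at least 1.1-fold lower number from compound 2 to compound 4 (0.05 log units; that floor lies within the scatter) is expected to stay within the scatter, with no clear direction. The expectation rests on compound 2, whose reading of > 160000 nM is a limit. A limit is also a likely outcome for the new measurement. For compound 4 the estimated value is 140000 nM, with an expected range of 70000 nM to 200000 nM.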

Compound 4, half-maximal inhibitory concentration: 167000 nM
Beside the measured number, compound 4's estimate is 1.2-fold (0.08 log units) below it, and the stated range covers the measured number.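

In this assay, for the compounds shown here, compound 2 has only the limit > 160000 nM and no number, and no step from compound 2 to compound 4 can be read. The compounds shown leave open how 4,4-dimethyl-1,3-oxazolidin-3-yl and 2,6-dimethylmorpholin-4-yl compare on the shared core in this assay when both carry numerical readings.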